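Removing a hydroxy from compound 3: what to expect

This account rests on a few compounds, and the source may have more. Where it says the series, first, only, none or still open, it means among the compounds named here.

Measured compounds:
compound 1 `CC(C)[C@@H](O)[C@H](O)C(=O)NS(=O)(=O)OC[C@H]1O[C@@H](n2cnc3c(N)ncnc32)C[C@@H]1O` — 6270 nM
compound 2 `CC(C)C[C@H](O)C(=O)NS(=O)(=O)OC[C@H]1O[C@@H](n2cnc3c(N)ncnc32)[C@H](O)[C@@H]1O` — 2610 nM
compound 3 `CC(C)[C@@H](O)[C@H](O)C(=O)NS(=O)(=O)OC[C@H]1O[C@@H](n2cnc3c(=O)[nH]cnc32)[C@H](O)[C@@H]1O` — > 20000 nM

Of the compounds shown here, three sharing one core have been measured in a functional assay on MDA-MB-231 cells (Homo sapiens) for antiproliferative activity, read by sulforhodamine B assay, with a stated time of 72 h; a lower number here means a stronger inhibitor, a higher number a weaker inhibitor. Compound 1 gives 6270 nM in this assay, and compound 2 gives 2610 nM; these two differ from each other in more than one place, so their values are simply noted side by side. Compound 3 gives only a limit in this assay, > 20000 nM, and so it is the compound about which the least is known: it sits at the limit of this assay, (the limit of > 20000 nM in this assay, at which 1 of the 3 values shown sits), where one of the three values stands.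

Compound 4 `CC(C)C[C@H](O)C(=O)NS(=O)(=O)OC[C@H]1O[C@@H](n2cnc3c(=O)[nH]cnc32)[C@H](O)[C@@H]1O` is not yet measured. It differs from compound 3 by hydrogen in place of hydroxy on a saturated chain carbon bound to two saturated chain carbons. Among the compounds with values here, no measured pair differs in one place only, so no step is available to calibrate this change. With compound 3 already at the limit, compound 4 is expected to stay weak in this assay, with the step of a number no higher from compound 3 to compound 4 (the limit leaves the size open) expected to be small or within the scatter. The estimate for compound 4 in this assay is 20000 nM, ranging from 7000 nM to 60000 nM.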

Compound 4, half-maximal inhibitory concentration: > 20000 nM
Compound 4: only a limit was reported; the forecaster's own chance of this, stated with the estimate: 60%; the middle value sits exactly at the limit.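

The hydroxy change itself stays out of reach: compound 3 and compound 4 both stand at a limit, and the step between them cannot be read, so hydrogen in place of hydroxy on a saturated chain carbon bound to two saturated chain carbons has no measured size in this assay. The count of compounds at that limit now reads: the limit of > 20000 nM in this assay, at which 2 of the 4 values shown sit.

Within the data shown here, the result does supply the first step that can be read, an at least 7.6-fold higher number from compound 2 to compound 4 (0.88 log units; beyond the scatter), with the isobutyl end held constant. This step belongs to the other place in the molecule, on a saturated ring carbon, where the group of 10 heavy atoms with 4 nitrogen and 1 oxygen stands in place of the group with 5 nitrogen.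

On these data alone, whether a methoxy or an amine on that saturated chain carbon, or a longer chain in place of isobutyl, would give a value clear of the limit remains open. The compounds shown also leave open how the 1-hydroxy-2-methylpropyl to isobutyl change acts on a core that gives a measurable value in this assay.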